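Weak antiproliferative compounds and one untested group swap

The source may hold more compounds than are shown below. What is called first, only, known or untested is meant among the compounds shown, and "the series" means these compounds.

Measured in a functional assay on IMR-32 cells (Homo sapiens) for antiproliferative activity, read by MTT assay; a lower number here means a stronger inhibitor, a higher number a weaker inhibitor:
- Compound 1 `CC1(C)CCc2c(ccc(C(=O)/C=C/c3ccc(OCc4cn(-c5ccc(Cl)cc5)nn4)cc3)c2O)O1` gives "not active" (no number reported)
- Compound 2 `CC1(C)CCc2c(ccc(C(=O)/C=C/c3ccc(OCc4cn(-c5ccc(Br)cc5)nn4)cc3)c2O)O1` gives 117000 nM
- Compound 3 `CC(=O)c1ccc(-n2cc(COc3ccc(/C=C/C(=O)c4ccc5c(c4O)CCC(C)(C)O5)cc3)nn2)cc1` gives 89600 nM

Within the data shown here, compound 3, at 89600 nM, lies within the scatter of compound 2, and these are the only two numbers available. Compound 1 has no number at all.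

The next structure is compound 4 `CCc1ccccc1-n1cc(COc2ccc(/C=C/C(=O)c3ccc4c(c3O)CCC(C)(C)O4)cc2)nn1`, which keeps everything else and puts 2-ethylphenyl in place of 4-acetylphenyl on an aromatic nitrogen.

Among the measured compounds shown here, only one measured step bears on this: a 1.3-fold lower number from compound 2 to compound 3 (0.12 log units; within the scatter), with acetyl in place of bromo on an aromatic carbon. For the measured compounds named here, that is thin evidence, since no measured compound carries 2-ethylphenyl. Compound 1 also goes against any claim of steady values, so a result without a number remains possible here.

No step beyond the scatter is therefore expected in this assay, and no direction can be favoured. The expected change is a 1.1-fold higher number from compound 3 to compound 4 (0.05 log units; within the scatter). For compound 4 the estimated value is 100000 nM, with an expected range of 45000 nM to 220000 nM.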

Compound 4, half-maximal inhibitory concentration: "not active" (no number reported)
For compound 4 the study gives words and no number; there is nothing to compare the estimate with.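

In this assay, among these compounds, compound 4 gives "not active" (no number reported) and no number, so no step from compound 3 to compound 4 can be read. The compounds shown leave open which groups on the aromatic nitrogen give a result with a number. Nothing given here explains this outcome.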